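The source may report more compounds than this note shows. Statements on the series, on what has been measured and on what is new or still open speak of the compounds shown alone.

Measured compounds:
Compound 1, `O=C(NC/C=C1\CCCc2cnn(-c3ccc(C(F)(F)F)cc3)c21)NS(=O)(=O)c1cc(Cl)c(Cl)s1`: 0.4 nM
Compound 2, `COc1ccc(S(=O)(=O)NC(=O)NC/C=C2\CCCc3cnn(Cc4ccc(Cl)cc4Cl)c32)cc1`: 10 nM

Of the compounds shown here, two have been measured in an assay on isolated protein for displacement of a labelled ligand from prostaglandin E2 receptor EP3 subtype (Homo sapiens), read by scintillation counting, with a stated time of 2 h; on this read-out lower numbers stand for stronger inhibition and higher numbers for weaker inhibition. Compound 1 gives 0.4 nM in this assay. Compound 2 gives 10 nM, the higher of the two numbers; its nearest neighbour is compound 1, whose number lies well below it, beyond the usual scatter. The two compounds differ in more than one place, so the gap between them cannot be traced to a single change.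

Compound 3, `Cc1ncc(S(=O)(=O)NC(=O)NC/C=C2\CCCc3cnn(Cc4ccc(Cl)cc4Cl)c32)s1`, has not yet been measured in this assay. It differs from compound 2 in one place: 2-methyl-1,3-thiazol-5-yl in place of 4-methoxyphenyl on a sulfonyl sulfur. Among the measured compounds shown here, no measured pair shows the effect of this change on its own, and compound 1 cannot serve as a guide since it differs from compound 2 elsewhere too. On the numbers at hand, the step of a 1.3-fold lower number from compound 2 to compound 3 (0.10 log units; within the scatter) is expected to stay within the scatter, with no clear direction. Compound 3 is therefore estimated at 8 nM in this assay, with a range from 2 nM to 40 nM.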

Compound 3, inhibition constant: 7 nM
For compound 3 the middle estimate is 1.1-fold (0.06 log units) above the measured one; measured number inside the range.
By their numbers in this assay, from the lowest: compound 1; then compounds 3 and 2 (each within the scatter of the next).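

In this assay, among the compounds shown here, putting 2-methyl-1,3-thiazol-5-yl in place of 4-methoxyphenyl on the sulfonyl sulfur gives a 1.4-fold lower number from compound 2 to compound 3 (0.15 log units; within the scatter), and this is the first pair in which the change can be read on its own, with the rest of the molecule held the same. At this position, then, a five-membered aromatic ring with 2 hetero atoms can stand in for a six-membered aromatic ring of carbon only without a change that this read-out can separate from the scatter, even though the methoxy oxygen leaves and a ring nitrogen and sulfur enter. No measurement shown bears on why the two groups read alike.

As far as these compounds go, whether this tolerance extends to groups of another kind on the sulfonyl sulfur remains open, for example a plain methyl, a cyclopropyl ring or a phenyl ring carrying a carboxylic acid. Compound 1 differs from compound 3 in more than one place, so it does not show how much of its value belongs to the group on the sulfonyl sulfur and how much to the other end of the molecule.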